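Cytotoxicity notes on a pyrimidinone thioether series

The compounds below may be only part of what the source reports. "The series", "measured", "known", "first", "only" and "open" are said of these compounds alone.

Measured compounds in an ADME assay on MT4 cells (Homo sapiens) for cytotoxicity; a higher number here means that more compound is tolerated, a lower number that less compound is tolerated:
- compound 1, `COc1ccc(C(=O)CSc2nc(Cc3cc(C)cc(C)c3)c(C)c(=O)[nH]2)cc1`, gives > 308000 nM, a limit of the assay.
- compound 2, `COc1ccc(C(=O)CSc2nc(Cc3cc(C(F)(F)F)cc(C(F)(F)F)c3)c(C)c(=O)[nH]2)cc1`, gives > 242000 nM, a limit of the assay.
- compound 3, `CCc1c(Cc2cc(C)cc(C)c2)nc(SCC(=O)c2ccc(OC)cc2)[nH]c1=O`, gives >= 239000 nM, a limit of the assay.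

Among the measured compounds shown here, all three values recorded so far are limits, not numbers; no compound in the set has reached a measurable half-maximal cytotoxic concentration. The step from compound 1 to compound 3 is methyl in place of hydrogen on a saturated chain carbon bound to an aromatic carbon; in this assay it reads a step that the two limits leave unreadable from compound 1 to compound 3, since the limit of > 308000 nM in this assay, at which 1 of the 3 values shown sits, and the limit of >= 239000 nM in this assay, at which 1 of the 3 values shown sits, both sit at limits. The difference between the core of compound 1 and the core of compound 2 is not broken down here.

Compound 4, `CCc1c(Cc2cc(C(F)(F)F)cc(C(F)(F)F)c2)nc(SCC(=O)c2ccc(OC)cc2)[nH]c1=O`, is not yet measured. Its difference from compound 2 is methyl in place of hydrogen on a saturated chain carbon bound to an aromatic carbon, the same change as from compound 1 to compound 3, made at the same place. For compound 4 the step is expected to be a step that the limit leaves unreadable from compound 2 to compound 4, resting on compound 2 at the limit of > 242000 nM in this assay, at which 1 of the 3 values shown sits, and on the unreadable step from compound 1 to compound 3 in this assay. Compound 4 is therefore expected to give about 250000 nM in this assay, with a range of 120000 nM to 600000 nM, and most likely as a limit again rather than a number.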

Compound 4, half-maximal cytotoxic concentration: > 236000 nM
Compound 4: a limit, no number; the forecaster's own chance of this, stated with the estimate: 85%; the middle value lies beyond the limit too.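

In this assay compound 4 gives > 236000 nM, a limit of the assay and not a number. Compound 2 also stands at a limit, > 242000 nM, so no step can be read between compound 2 and compound 4. The compounds shown leave open where any half-maximal cytotoxic concentration in this series lies, and whether methyl in place of hydrogen at this place shifts it at all.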